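A trifluoromethyl on the phenyl ring of compound 3

The compounds below may be only part of what the source reports. "The series", "measured", "known", "first", "only" and "open" are said of these compounds alone.

Of the compounds shown here, three sharing one core have been measured. Compound 1 `CC(/N=c1\c(O)c(O)\c1=N/c1cccnc1O)C(C)(C)C` carries a 2-hydroxypyridin-3-yl group on a double-bonded nitrogen; in a functional assay for inhibition, with Rattus norvegicus as the target (on this read-out lower numbers stand for stronger inhibition and higher numbers for weaker inhibition), compound 1 gives only a limit of the assay, > 30000 nM, not a number. Compound 2 `C[C@@H](/N=c1\c(O)c(O)\c1=N/c1ccc2[nH]ncc2c1)C(C)(C)C` gives 740 nM in this assay, and compound 3 `CC(/N=c1\c(O)c(O)\c1=N/c1ccccc1)C(C)(C)C`, with a plain phenyl group, gives 5400 nM. Among the numbers shown, compound 3 stands as the highest of the two, with compound 2 giving the lower number by a step beyond the scatter. Among the compounds with values here, the one measured step, an at least 5.5-fold lower number from compound 1 to compound 3 (0.74 log units; beyond the scatter), concerns the whole ring on the double-bonded nitrogen, not a group added to it.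

Compound 4 `CC(/N=c1\c(O)c(O)\c1=N/c1ccc(C(F)(F)F)cc1)C(C)(C)C` differs from compound 3 by a single change: trifluoromethyl in place of hydrogen on an aromatic carbon. Within the data shown here, no measured step involves adding a group to this ring, so nothing seen here tells the direction of the change. The expected step of a 1.4-fold lower number from compound 3 to compound 4 (0.13 log units; within the scatter) is therefore none beyond the scatter. For compound 4 the estimate in this assay is 4000 nM, within a range from 800 nM to 20000 nM.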

Compound 4, half-maximal inhibitory concentration: > 30000 nM
Compound 4 was reported as a limit; the forecaster's own chance of this, stated with the estimate: 10%; middle value at least 7.5-fold (0.87 log units) away from the limit.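

The para position of the phenyl ring is not indifferent in this assay: trifluoromethyl in place of hydrogen gives an at least 5.5-fold higher number from compound 3 to compound 4 (0.74 log units; beyond the scatter), which means weaker inhibition. The earlier step exchanged one whole ring for another, whereas this one adds a single group to the phenyl ring and still moves the read-out beyond the scatter. The value of compound 4 is a limit, not a number, and it is not alone there: the limit of > 30000 nM in this assay, at which 2 of the 4 values shown sit.

From the compounds shown here alone, whether this weakening belongs to trifluoromethyl itself or would come with any group at this place stays open, and a methyl, a methoxy or an amine on the same carbon would help to separate the two. The compounds shown also leave open how trifluoromethyl would behave on another carbon of the phenyl ring.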